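This account rests on a few compounds, and the source may have more. Where it says the series, first, only, none or still open, it means among the compounds named here.

Compound 1 `CC(C)(C)C#Cc1cc(N(C(=O)[C@H]2CC[C@H](C)CC2)[C@H]2CC[C@H](Oc3ccc4nccn4n3)CC2)c(C(=O)O)s1`: > 20000 nM
Compound 2 `CC(C)(C)C#Cc1cc(N(C(=O)[C@H]2CC[C@H](C)CC2)[C@H]2CC[C@@H](Oc3ccc(=O)[nH]n3)CC2)c(C(=O)O)s1`: > 20000 nM
Compound 3 `CC1=CC[C@H](C(=O)N(c2cc(C#CC(C)(C)C)sc2C(=O)O)[C@H]2CC[C@](O)(CO[C@H]3CCOC3)CC2)CC1`: > 20000 nM

All three compounds were tested in an ADME assay on MT4 cells (Homo sapiens) for cytotoxicity, with a stated time of 5 days; on this read-out lower numbers stand for higher toxicity in this test and higher numbers for lower toxicity in this test. Compound 1 stands at > 20000 nM, and this is a limit of the assay, not a number. The same holds across the set, which shows (the limit of > 20000 nM in this assay, at which 3 of the 3 values shown sit). The three compounds therefore cannot be put in order.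

Compound 4 `CC(C)(C)C#Cc1cc(N(C(=O)[C@H]2CC[C@H](C)CC2)[C@H]2CC[C@H](OC3CCOC3)CC2)c(C(=O)O)s1` has not yet been measured. It keeps the core of compound 1 and differs in one place: a group of 5 heavy atoms (4 carbon, 1 oxygen; one five-membered non-aromatic ring with 1 hetero atom) in place of a group of 9 heavy atoms (6 carbon, 3 nitrogen; one five-membered aromatic ring with 2 hetero atoms, one six-membered aromatic ring with 2 hetero atoms), on an oxygen on a saturated carbon. Put simply, on an oxygen on a saturated carbon, a group of two aromatic rings gives way to oxolan-3-yl, which has fewer heavy atoms.

In this assay, no step beyond the usual scatter is expected for this change. This expectation rests mainly on compound 3, which also carries an oxolan-3-yl group and whose > 20000 nM is a limit. The estimated step, a step that the limit leaves unreadable from compound 1 to compound 4, is expected to stay within the scatter. A limit rather than a number is the most likely report. Expressed as a value, compound 4 is estimated at 22000 nM, with an expected range from 12000 nM to 40000 nM.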

Compound 4, half-maximal cytotoxic concentration: > 20000 nM
Compound 4 was reported as a limit; the forecaster's own chance of this, stated with the estimate: 80%; the middle value lies beyond the limit too.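

In this assay, compound 1 and compound 4 are both reported as limits rather than numbers, and no step can be read between them. The whole set shows the same picture: the limit of > 20000 nM in this assay, at which 4 of the 4 values shown sit. The compounds shown leave open how far any of them differs in this assay, including whether replacing the group of two aromatic rings with oxolan-3-yl changes the read-out at all.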